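The source may report more compounds than this note shows. Statements on the series, on what has been measured and on what is new or still open speak of the compounds shown alone.

Working notes on the series. In an assay on isolated protein for inhibition of aldehyde dehydrogenase 1A1 (Homo sapiens), read by spectrophotometry, tested at 10 uM (on this read-out higher numbers stand for more inhibition at the one concentration tested (going by the name of the read-out) and lower numbers for less inhibition), compound 1 `Cc1cccc(Cn2c(CN3CCN(C(=O)c4cccs4)CC3)nc3ccccc32)c1` gives 60.8% and compound 2 `CC(C)Cn1c(CN2CCN(C(=O)C3CC3)CC2)nc2ccccc21` gives 13.1%. Within the data shown here, compound 2 therefore stands lowest of the two numbers so far; its nearest neighbour is compound 1, whose value lies beyond the scatter above it. Among the measured compounds shown here, no single-point step between the two measured compounds is available, as they differ in more than one place, so the comparison says only that compound 1 is the higher of the pair.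

Compound 3 `O=C(C1CC1)N1CCN(Cc2nc3ccccc3n2Cc2ccc(C(F)(F)F)cc2)CC1` is not yet measured in this assay. It departs from compound 2 by 4-(trifluoromethyl)phenyl in place of isopropyl on a saturated chain carbon bound to an aromatic nitrogen. For the measured compounds named here, with no measured step to lean on, the size of the change from compound 2 to compound 3 is open; a moderate rise in inhibition is expected, as a number 21.9 percentage points higher from compound 2 to compound 3 (beyond the scatter), though a result within the scatter of compound 2 would not surprise. For compound 3 the expected value in this assay is 35%, with a range of 10% to 65%.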

Compound 3, a percentage reported as inhibition, at one concentration (the size of the read-out at that concentration, not a potency): 37%
Beside the measured number, compound 3's estimate is 2 percentage points below it; measured number inside the range.
By their numbers in this assay, from the lowest: compound 2; then compound 3; then compound 1.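

In this assay, this position on a saturated chain carbon bound to an aromatic nitrogen now has its first single-place step: a number 23.9 percentage points higher from compound 2 to compound 3 (beyond the scatter), with 4-(trifluoromethyl)phenyl in place of isopropyl and the rest of the structure held constant. The result shows that inhibition in this series changes with the group at this position, which the comparison of compound 1 and compound 2 could not show, as those compounds differ in more than one place. The aromatic ring and the trifluoromethyl group enter together, and nothing here gives a reason for the rise or separates their contributions.

The compounds shown leave open whether a plain phenyl group would give the same step as 4-(trifluoromethyl)phenyl. They also leave open how a carboxylic acid or a longer alkyl chain at this position would read out.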